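A Carboxyethyl Amide Variant of a Weakly Cytotoxic Series

The compounds below may be only part of what the source reports. "The series", "measured", "known", "first", "only" and "open" are said of these compounds alone.

Of the compounds shown here, three sharing one core have been measured in a functional assay on MCF7 cells (Homo sapiens) for cytotoxicity, read by MTT assay, with a stated time of 24 h; on this read-out lower numbers stand for stronger inhibition and higher numbers for weaker inhibition. Compound 1 `CNC(=O)Cn1nc(N)c2c(C(F)(F)F)cc(-c3ccccc3)nc21` gives 11800 nM, the highest of the three numbers. Compound 2 `Nc1nn(CC(=O)NCc2ccco2)c2nc(-c3ccccc3)cc(C(F)(F)F)c12` gives 5000 nM, and compound 3 `Nc1nn(CC(=O)N2CCOCC2)c2nc(-c3ccccc3)cc(C(F)(F)F)c12` gives 5900 nM. The two departures from compound 1 both alter the amide end of the side chain: a 2.4-fold lower number from compound 1 to compound 2 (0.37 log units; beyond the scatter), while a 2.0-fold lower number from compound 1 to compound 3 (0.30 log units; within the scatter). Between the two altered amides, a 1.2-fold higher number from compound 2 to compound 3 (0.07 log units; within the scatter).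

Compound 4 `CC(NC(=O)Cn1nc(N)c2c(C(F)(F)F)cc(-c3ccccc3)nc21)C(=O)O` differs from compound 1 in the same region: 1-carboxyethyl in place of methyl on an amide-type nitrogen. The measured steps that bear on it are the two changes at the amide, and both moved the number down only modestly, one of them within the scatter. Going by the values given here, no measured compound carries a 1-carboxyethyl group or anything resembling it, so the data give no direct guide to its effect. Given that the amide changes in this assay have produced small downward movements at most, compound 4 is expected to sit close to compound 1, with a 1.2-fold lower number from compound 1 to compound 4 (0.07 log units; within the scatter) regarded as the likely outcome, leaning slightly lower rather than higher. Compound 4 is therefore estimated at 10000 nM in this assay, with a range from 4000 nM to 30000 nM.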

Compound 4, half-maximal inhibitory concentration: 19900 nM
Compound 4: middle estimate off by 2.0-fold (0.30 log units), on the low side, within the range that was stated.
By their numbers in this assay, from the lowest: compounds 2, 3, 1 and 4 (each within the scatter of the next, the first and the last beyond it).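

In this assay, going by these compounds alone, 1-carboxyethyl is the first group on this amide-type nitrogen to end in a carboxylic acid, and replacing methyl with it gives a 1.7-fold higher number from compound 1 to compound 4 (0.23 log units; within the scatter), so this larger group cannot be told apart from methyl at this position. The same group does separate from the two other amides, with a 3.4-fold higher number from compound 3 to compound 4 (0.53 log units; beyond the scatter) and a 4.0-fold higher number from compound 2 to compound 4 (0.60 log units; beyond the scatter), which shows that changes at the amide end can span a spread beyond the scatter, though a modest one, and that 1-carboxyethyl lies at the high end of that spread, alongside methyl rather than the furan-2-yl or morpholin-4-yl amides. Nothing available explains why these amides differ.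

The compounds shown leave open whether the carboxylic acid or the branching methyl of the 1-carboxyethyl group goes with the higher number, a question that the methyl ester of the same chain or a plain carboxymethyl group on this nitrogen would help to settle. They also leave open how a primary amine at the end of a longer chain on this nitrogen would compare with the furan-2-yl and morpholin-4-yl amides.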